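Phenyl for amino on the ring nitrogen: compound 4

The source may hold more compounds than are shown below. What is called first, only, known or untested is meant among the compounds shown, and "the series" means these compounds.

Compound 3 `Cc1cc(C)n2nc(SCc3nnc(SCc4cc(=O)c5ccccc5o4)n3N)nc2n1` stands at a limit in a functional assay on SW480 cells (Homo sapiens) for cytotoxicity, read by MTT assay, with a stated time of 72 h; a lower number here means a stronger inhibitor, a higher number a weaker inhibitor: compound 3 gives > 25000 nM, which is a limit and not a number. Compound 2 `Cc1nnc(SCc2cc(=O)c3ccccc3o2)o1` also gives only a limit, > 25000 nM. Compound 1 `Cc1cc(C)n2nc(SCc3nnc(SCc4coc5ccccc5c4=O)n3-c3ccccc3)nc2n1` carries a phenyl on the same ring nitrogen as compound 4 but differs elsewhere; in this assay compound 1 gives 12400 nM. Two of the three values shown sit at the limit of > 25000 nM in this assay, at which 2 of the 3 values shown sit, so compound 3 cannot be placed against compound 2 beyond saying that both are limits.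

Compound 4 `Cc1cc(C)n2nc(SCc3nnc(SCc4cc(=O)c5ccccc5o4)n3-c3ccccc3)nc2n1` differs from compound 3 by phenyl in place of amino on an aromatic nitrogen. No measured step for this change is shown. The step from compound 3 to compound 4 is expected to be an at least 1.5-fold lower number from compound 3 to compound 4 (0.19 log units; that floor lies within the scatter), towards a stronger inhibitor, since compound 1 with the same phenyl reaches a measurable 12400 nM. Compound 4 is therefore estimated at 16000 nM, with a range from 6000 nM to 40000 nM, and a fair chance that only a limit is returned.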

Compound 4, half-maximal inhibitory concentration: > 25000 nM
Compound 4 ended at the assay's limit; the forecaster's own chance of this, stated with the estimate: 45%; middle value at least 1.5-fold (0.19 log units) away from the limit.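

In this assay the phenyl in place of amino on an aromatic nitrogen yields no readable change, and the step between the two limits cannot be read: the limit of > 25000 nM in this assay, at which 3 of the 4 values shown sit.

With that phenyl held fixed, exchanging the group of 11 heavy atoms on a saturated chain carbon bound to a sulfur gives an at least 2.0-fold higher number from compound 1 to compound 4 (0.30 log units; that floor lies within the scatter). On these data alone, the phenyl alone is thus not enough for a value like that of compound 1, 12400 nM, although the size of this step remains open.

As far as these compounds go, whether a methyl or a benzyl on this aromatic nitrogen would give a readable value with the side group of compound 4 stays open. Also open, from the compounds shown here alone, is how an amino on this nitrogen would read with the side group of compound 1.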